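Adding a Second Methoxy Beside the Phenol

The source may hold more compounds than are shown below. What is called first, only, known or untested is meant among the compounds shown, and "the series" means these compounds.

Of the compounds shown here, two have been tested in a functional assay on HepG2 cells (Homo sapiens) for antiproliferative activity, read by sulforhodamine B assay, with a stated time of 48 h; a higher number here means a weaker inhibitor, a lower number a stronger inhibitor. Compound 1 `COc1ccc(/C=C/C(=O)C(=Cc2ccc(O)c(F)c2)C(=O)/C=C/c2ccc(OC)cc2OC)c(OC)c1` gives 1760 nM. Compound 2 `COc1cc(OC)c(/C=C/C(=O)C(=Cc2ccc(O)c(OC)c2)C(=O)/C=C/c2c(OC)cc(OC)cc2OC)c(OC)c1` gives 670 nM, the lower of the two numbers; compound 1 stands a clear step higher, beyond the usual scatter. Compound 3 `COc1cc(OC)c(/C=C/C(=O)C(=Cc2cc(OC)c(O)c(OC)c2)C(=O)/C=C/c2c(OC)cc(OC)cc2OC)c(OC)c1` has not yet been measured. It differs from compound 2 in one place: methoxy in place of hydrogen on an aromatic carbon. Among the measured compounds shown here, no measured pair shows what this change does, so compound 3 is expected to stay close to compound 2, with a step of a 1.1-fold lower number from compound 2 to compound 3 (0.05 log units; within the scatter) in this assay, that is, none beyond the scatter. The estimate for compound 3 is 600 nM, ranging from 250 nM to 1500 nM.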

Compound 3, half-maximal inhibitory concentration: 510 nM
Compound 3: middle estimate off by 1.2-fold (0.07 log units), on the high side; the measured number falls inside the stated range.
By their numbers in this assay, from the lowest: compounds 3 and 2 (each within the scatter of the next); then compound 1.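

The change from 4-hydroxy-3-methoxyphenyl to 4-hydroxy-3,5-dimethoxyphenyl now has a direct reading in this assay: a 1.3-fold lower number from compound 2 to compound 3 (0.12 log units; within the scatter). In this one pair, a methoxy on this aromatic carbon, ortho to the hydroxy group, is therefore tolerated without a step beyond the scatter. No supporting evidence is available to explain this result.

On these data alone, whether an amine or a longer ethoxy chain on this same carbon would also stay within the scatter remains open.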